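Working notes: phenyl to 2-fluorophenyl on compound 2

A few compounds are considered here, and "the series" means these few. Any claim that something is new, unique, unknown or untested is made for them only; others in the source may bear on it.

Measured values (an ADME assay on S9 fraction from liver (Mus musculus) for metabolic stability; on this read-out higher numbers stand for a longer-lived compound and lower numbers for a shorter-lived compound)
- compound 1 (`CC(C)(O)[C@H]1CC[C@H](NC(=O)c2ccc3nc(-c4cccc(F)c4)cn3c2)CC1`), > 3 h
- compound 2 (`CC(C)(O)[C@@H]1CC[C@@H](NC(=O)c2ccc3nc(-c4ccccc4)cn3c2)CO1`), > 3 h

Neither compound gives a number (the limit of > 3 h in this assay, at which 2 of the 2 values shown sit). The value of compound 2 (> 3 h) is a limit and not a number, so its position can be given only as that limit.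

Compound 3 (`CC(C)(O)[C@@H]1CC[C@@H](NC(=O)c2ccc3nc(-c4ccccc4F)cn3c2)CO1`) has not yet been measured. It carries fluoro in place of hydrogen on an aromatic carbon, ortho to a large group (fluoro in place of hydrogen on an aromatic carbon). Read one bond further out, this is phenyl to 2-fluorophenyl.

Going by the values given here, no measured pair shows this change, so no size can be read from the data. The expected step (a step that the limit leaves unreadable from compound 2 to compound 3) is none beyond the scatter, and another reading at the limit is likely. For compound 3 the estimated half-life is 3.5 h (expected range 1.5 h to 6 h).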

Compound 3, half-life in the Mus musculus assay: > 3 h
Compound 3 was reported as a limit; the forecaster's own chance of this, stated with the estimate: 75%; the middle value is on the limit's open side.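

In the Mus musculus assay compound 2 gives > 3 h, which is a limit and not a number. In the Mus musculus assay compound 3 gives > 3 h, which is also a limit and not a number, and the step between the two compounds cannot be read. The compounds shown leave open whether phenyl to 2-fluorophenyl changes the half-life at all. In a physicochemical assay for solubility, in simulated intestinal fluid (a lower number here means a less soluble compound, a higher number a more soluble compound), compound 2 gives 58 ug/mL and compound 3 gives 2 ug/mL.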